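Methylating the Phenol of Compound 3

The source may hold more compounds than are shown below. What is called first, only, known or untested is meant among the compounds shown, and "the series" means these compounds.

Compound 3 `COc1cc(Cn2cc(C[N+](C)(C)C)c3ccccc32)ccc1O` stands second highest of the three numbers in an assay on HEK293 cells for antagonist activity at Neuronal acetylcholine receptor; alpha4/beta2 (Homo sapiens), read by calcium flux (on this read-out lower numbers stand for stronger inhibition and higher numbers for weaker inhibition), giving 9100 nM. Compound 2 `COc1ccc(Cn2cc(C[N+](C)(C)C)c3ccccc32)cc1O` gives 9500 nM, a gap within the scatter, while compound 1 `COc1ccc(Cn2cc(C[N+](C)(C)C)c3ccccc32)cc1` gives 4400 nM, the lowest of the three. Compound 4 `COc1ccc(Cn2cc(C[N+](C)(C)C)c3ccccc32)cc1OC` differs from compound 3 by methyl in place of hydrogen on an oxygen on an aromatic ring. Within the data shown here, the only measured step, a 2.2-fold higher number from compound 1 to compound 2 (0.33 log units; beyond the scatter), concerns adding a hydroxy rather than capping one with methyl, so it bears on the present change only loosely. Among the measured compounds shown here, compound 2 and compound 3 both sit above compound 1; capping the hydroxy might move the number part of the way back toward compound 1, but no step shows this directly. Compound 4 is therefore expected to give 5500 nM, within 2500 nM to 12000 nM, a step of a 1.7-fold lower number from compound 3 to compound 4 (0.22 log units; within the scatter) expected to stay small.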

Compound 4, half-maximal inhibitory concentration: 14800 nM
The estimate for compound 4 lay 2.7-fold (0.43 log units) below the measured number; the whole stated range lies below it.
By their numbers in this assay, from the lowest: compound 1; then compounds 3, 2 and 4 (each within the scatter of the next).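

In this assay, methyl on the hydroxy oxygen did not return the number toward that of compound 1: a 1.6-fold higher number from compound 3 to compound 4 (0.21 log units; within the scatter) and a 1.6-fold higher number from compound 2 to compound 4 (0.19 log units; within the scatter) both lie within the scatter, so compound 4 cannot be told apart from either hydroxy compound. Only a 3.4-fold higher number from compound 1 to compound 4 (0.53 log units; beyond the scatter) lies beyond it, so methoxy, like hydroxy in a 2.2-fold higher number from compound 1 to compound 2 (0.33 log units; beyond the scatter), goes with a higher number than hydrogen on that aromatic carbon. Nothing available explains this. As far as these compounds go, whether an amine or a longer chain such as ethoxy would behave likewise remains open.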